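Swapping a Benzyl Amine for an Aryl Amine

This account rests on a few compounds, and the source may have more. Where it says the series, first, only, none or still open, it means among the compounds named here.

Measured compounds:
compound 1, `Cc1ccccc1Nc1nc(Nc2ccc(N3CCN(C)CC3)cc2)ncc1Cl`, 6510 nM
compound 2, `Cc1ccccc1Nc1nc(Nc2ccc(N3CCCCC3)cc2)ncc1Cl`, 5690 nM
compound 3, `COc1ccc(CNc2nc(Nc3ccc(N4CCN(C)CC4)cn3)ncc2Cl)cc1`, 12900 nM

All three were tested in an ADME assay on L02 cells (Homo sapiens) for inhibition, read by CCK-8 assay, with a stated time of 48 h; a lower number here means a stronger inhibitor of growth, a higher number a weaker inhibitor of growth. Compound 3 stands at the highest number of the three: its gap to compound 1 lies within the usual scatter, while its gap to compound 2 lies beyond it. Among the compounds with values here, the one step between two measured compounds that differ in a single place, a 1.1-fold lower number from compound 1 to compound 2 (0.06 log units; within the scatter), concerns a ring at the far end of the shared core and stays within the scatter.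

Compound 4, `COc1ccc(Nc2nc(Nc3ccc(N4CCN(C)CC4)cn3)ncc2Cl)cc1`, differs from compound 3 in one place:
4-methoxyphenyl in place of 4-methoxybenzyl on a nitrogen on an aromatic ring

Within the data shown here, no measured step touches this kind of change. Compounds 1 and 2 do carry an aryl group on the corresponding nitrogen, as compound 4 does, and both sit at lower numbers than compound 3; but each of them also differs from compound 3 elsewhere, so they give only a loose hint. In this assay the step expected is a 1.4-fold lower number from compound 3 to compound 4 (0.16 log units; within the scatter), a modestly lower number that need not reach beyond the scatter. Compound 4 is estimated at 9000 nM, with a range from 4000 nM to 20000 nM.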

Compound 4, concentration for 50% growth inhibition: 3150 nM
For compound 4 the middle estimate is 2.9-fold (0.46 log units) above the measured one, outside the stated range (below it).
By their numbers in this assay, from the lowest: compounds 4, 2, 1 and 3 (each within the scatter of the next, the first and the last beyond it).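

In this assay, putting 4-methoxyphenyl in place of 4-methoxybenzyl on this nitrogen gives a 4.1-fold lower number from compound 3 to compound 4 (0.61 log units; beyond the scatter). The group on this nitrogen can therefore move the number beyond the scatter. Within the data shown here, the only earlier step, a 1.1-fold lower number from compound 1 to compound 2 (0.06 log units; within the scatter), changed a ring at a different place on the shared core and showed no change beyond the scatter, so it said nothing about this nitrogen. The size of the new step stands out. The two groups have much in common: each has one six-membered aromatic ring of carbon only, the same count of hydrogen-bond donors and acceptors, and no net charge. Nothing in the data shown accounts for the size of this step.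

This single pair cannot show whether the number keeps rising as the ring moves further from the nitrogen, which a longer chain such as 2-(4-methoxyphenyl)ethyl would test. It also leaves open whether the same swap has a similar effect when the ring carries a different group, such as a fluorine or a nitrile, in place of the methoxy.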